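Difluorophenyl replaces dimethoxyphenyl on the carbonyl carbon

The source may hold more compounds than are shown below. What is called first, only, known or untested is meant among the compounds shown, and "the series" means these compounds.

Compound 1 `COc1cc(-c2cc(/C=C/C(=O)c3ccc(Cl)c(Cl)c3)[nH]n2)cc(OC)c1OC`: > 100000 nM
Compound 2 `COc1ccc(C(=O)/C=C/c2cc(-c3cc(OC)c(OC)c(OC)c3)n[nH]2)cc1OC`: 6370 nM
Compound 3 `COc1cc(-c2cc(/C=C/C(=O)c3ccc(F)c(F)c3)[nH]n2)cc(OC)c1OC`: to be measured

Of the compounds shown here, two have been measured in a functional assay on SN12C cells (Homo sapiens) for inhibition, read by sulforhodamine B assay, with a stated time of 48 h; a lower number here means that less compound is tolerated, a higher number that more compound is tolerated. For compound 1 the value of > 100000 nM is a limit of the assay and not a number (the limit of > 100000 nM in this assay, at which 1 of the 2 values shown sits). Compound 2 gives 6370 nM in this assay, the only actual number shown. For the measured compounds named here, the one measured step, an at least 15-fold lower number from compound 1 to compound 2 (1.19 log units; beyond the scatter), shows what happens when a 3,4-dimethoxyphenyl takes the place of a 3,4-dichlorophenyl on the carbonyl carbon.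

Compound 3 carries the change (3,4-difluorophenyl in place of 3,4-dimethoxyphenyl on a carbonyl carbon). This runs the measured step backwards in kind: a halogen-bearing ring returns to the carbonyl carbon, now with fluorine rather than chlorine. Because an at least 15-fold lower number from compound 1 to compound 2 (1.19 log units; beyond the scatter) was large and pointed toward a lower number when the halogenated ring was removed, a large step in the opposite direction is expected here, toward a higher number in this assay, with a real chance that only a limit is reported again. Compound 3 is therefore estimated at 40000 nM in this assay, within 8000 nM to 150000 nM. The expected step of a 6.3-fold higher number from compound 2 to compound 3 (0.80 log units; beyond the scatter) reflects this.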

Compound 3, concentration lethal to 50% of the cells: > 100000 nM
Compound 3 gave a limit, no number; the forecaster's own chance of this, stated with the estimate: 40%; at least 2.5-fold (0.39 log units) between middle value and limit.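

In this assay, putting 3,4-difluorophenyl in place of 3,4-dimethoxyphenyl on the carbonyl carbon gives an at least 15-fold higher number from compound 2 to compound 3 (1.19 log units; beyond the scatter), so the large change at this position now appears with a second halogen-bearing ring and not only with 3,4-dichlorophenyl. Among the three compounds, only compound 2, with its 3,4-dimethoxyphenyl, gives an actual number, while the two dihalogenated compounds, compound 1 and compound 3, both stop at an assay limit rather than a number: the limit of > 100000 nM in this assay, at which 2 of the 3 values shown sit. For the compounds shown here, the step from compound 1 to compound 3 cannot be read, so the shared limit does not show that fluorine and chlorine are equivalent here, only that neither pair of halogens brings a number within the range of this assay.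

On these data alone, whether the methoxy groups themselves are what matters at this position remains open, and a phenyl ring carrying a single methoxy group would bear on that. As far as these compounds go, it is also open whether a ring carrying an amine, a hydroxyl group or a carboxylic acid on the carbonyl carbon would give a number in this assay, and how such a value would compare with that of compound 2.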